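Amine substituent on the shared core: compound 3 to compound 4

The compounds below may be only part of what the source reports. "The series", "measured", "known", "first", "only" and "open" are said of these compounds alone.

Compound 1 `O=C(CCc1ccc(C(F)(F)F)cc1)Nc1ccc2nc(N3CCC3)ccc2c1` carries azetidin-1-yl on the shared core; in a functional assay on HEK293 cells for activation of melanin-concentrating hormone receptor 1 (Rattus norvegicus), read by inositol phosphate accumulation (on this read-out lower numbers stand for an effect already at smaller amounts and higher numbers for an effect only at larger amounts of compound), compound 1 gives 56 nM. Compound 2 `O=C(CCc1ccc(C(F)(F)F)cc1)Nc1ccc2nc(N3CCC(NS(=O)(=O)O)C3)ccc2c1` carries 3-(sulfoamino)pyrrolidin-1-yl at that place, and in this assay compound 2 gives 50 nM, a step of a 1.1-fold lower number from compound 1 to compound 2 (0.05 log units; within the scatter). Compound 3 `CN(c1ccc2cc(NC(=O)CCc3ccc(C(F)(F)F)cc3)ccc2n1)C1CCCC1` carries cyclopentyl(methyl)amino there; in this assay compound 3 gives 350 nM, the highest number of the three, reached by a 6.3-fold higher number from compound 1 to compound 3 (0.80 log units; beyond the scatter) and by a 7.0-fold higher number from compound 2 to compound 3 (0.85 log units; beyond the scatter).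

Compound 4 `CN(C)c1ccc2cc(NC(=O)CCc3ccc(C(F)(F)F)cc3)ccc2n1` differs from compound 3 in one place: methyl in place of cyclopentyl on a nitrogen on an aromatic ring. Going by the values given here, no measured pair makes exactly this change. Among the compounds with values here, the steps that bear on it are the two that introduced cyclopentyl(methyl)amino in place of a ring amine, a 6.3-fold higher number from compound 1 to compound 3 (0.80 log units; beyond the scatter) and a 7.0-fold higher number from compound 2 to compound 3 (0.85 log units; beyond the scatter), both beyond the scatter and in the same direction. Taking the cyclopentyl away again, leaving dimethylamino, is expected to undo part of that, so a lower number is expected in this assay, roughly a 3.2-fold lower number from compound 3 to compound 4 (0.50 log units; beyond the scatter). An acyclic amine is not the same as the ring amines of compound 1 and compound 2, so the full return is not assumed. Compound 4 is therefore estimated at 110 nM in this assay, with a range of 40 nM to 300 nM.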

Compound 4, half-maximal effective concentration: 110 nM
Compound 4: middle estimate and measured number agree at the digits printed, within the range that was stated.
By their numbers in this assay, from the lowest: compounds 2, 1 and 4 (each within the scatter of the next, the first and the last beyond it); then compound 3.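

Read directly in this assay, removing the cyclopentyl from the nitrogen on an aromatic ring lowers the number (a 3.2-fold lower number from compound 3 to compound 4 (0.50 log units; beyond the scatter)), so the high value of compound 3 goes with cyclopentyl(methyl)amino and not with every open-chain amine at this position. Dimethylamino also stands within the scatter of azetidin-1-yl (a 2.0-fold higher number from compound 1 to compound 4 (0.29 log units; within the scatter)), which shows that a ring amine is not needed to reach that level, although 3-(sulfoamino)pyrrolidin-1-yl keeps a modest edge beyond the scatter (a 2.2-fold higher number from compound 2 to compound 4 (0.34 log units; beyond the scatter)). No measurement here offers an explanation for these steps.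

The compounds shown leave open how the number moves with substituents of intermediate size on this nitrogen, such as ethyl or isopropyl, and whether a single methyl with a hydrogen on the nitrogen would stay at the level of dimethylamino. They also leave open whether a larger ring amine such as piperidin-1-yl, or an unsubstituted pyrrolidin-1-yl that would separate the ring from its sulfoamino group, would stay at the level of compound 1 and compound 2.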